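Swapping the Cyanobenzyl Arm for a Pyridylpropargyl Chain

This account rests on a few compounds, and the source may have more. Where it says the series, first, only, none or still open, it means among the compounds named here.

Measured compounds:
compound 1 `COc1ccc(CNc2nc(-c3ccccc3C(F)(F)F)nc3ccccc23)cc1` — 6200 nM
compound 2 `N#Cc1ccc(CNc2nc(-c3ccccc3C(F)(F)F)nc3ccccc23)cc1` — 5700 nM

In an assay on a protein complex for inhibition of ubiquitin carboxyl-terminal hydrolase 1/WD repeat-containing protein 48 (Homo sapiens), read by fluorescence (a lower number here means a stronger inhibitor, a higher number a weaker inhibitor), compound 2 gives the lowest of the two numbers. Among the compounds with values here, its only neighbour, compound 1, is separated from it by a single change, cyano in place of methoxy on an aromatic carbon, and that step is a 1.1-fold lower number from compound 1 to compound 2 (0.04 log units; within the scatter). The two values therefore cannot be told apart, and no order between compound 1 and compound 2 is claimed.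

Compound 3 `FC(F)(F)c1ccccc1-c1nc(NCC#Cc2cccnc2)c2ccccc2n1` carries a different arm on the amine: 2-(pyridin-3-yl)ethynyl in place of 4-cyanophenyl on a saturated chain carbon bound to a nitrogen on an aromatic ring. Within the data shown here, the one measured step, from compound 1 to compound 2, only exchanged a substituent on the aromatic ring that now leaves entirely; it says nothing about replacing that ring with a 2-(pyridin-3-yl)ethynyl group. Among the measured compounds shown here, with no step bearing directly on this change, the expectation for compound 3 rests on the observation that the two measured arms gave matching numbers, so the estimated step is a 1.1-fold lower number from compound 2 to compound 3 (0.06 log units; within the scatter), a change no larger than the scatter but with a wide range. Compound 3 is thus expected at about 5000 nM, between 1500 nM and 16000 nM.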

Compound 3, half-maximal inhibitory concentration: 8900 nM
The estimate for compound 3 lay 1.8-fold (0.25 log units) below the measured number; the range from low to high includes it.
By their numbers in this assay, from the lowest: compounds 2, 1 and 3 (each within the scatter of the next).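

In this assay, 2-(pyridin-3-yl)ethynyl in place of 4-cyanophenyl on a saturated chain carbon bound to a nitrogen on an aromatic ring gives a 1.6-fold higher number from compound 2 to compound 3 (0.19 log units; within the scatter) and the same exchange for 4-methoxyphenyl gives a 1.4-fold higher number from compound 1 to compound 3 (0.16 log units; within the scatter), so neither step separates the new arm from the older ones. The earlier pair altered only a substituent on an aromatic ring of carbon only, whereas these steps show that replacing that whole ring with an alkyne-linked ring holding one hetero atom, at the same count of heavy atoms, leaves all three compounds indistinguishable at this position. Nothing available bears on why these numbers stay together.

What the compounds leave open is whether any arm at this position can shift the number beyond the scatter, since all three arms keep an aromatic ring and compound 1, compound 2 and compound 3 share the same core. A saturated propyl chain in place of the alkyne, a phenyl in place of the pyridin-3-yl, or a carboxylic acid or an amine on the ring of the arm would each test this further.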